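The source may hold more compounds than are shown below. What is called first, only, known or untested is meant among the compounds shown, and "the series" means these compounds.

Measured so far in a functional assay on HCT-116 cells (Homo sapiens) for antiproliferative activity, read by colorimetric assay and sulforhodamine B assay, with a stated time of 3 days; on this read-out higher numbers stand for weaker inhibition and lower numbers for stronger inhibition:
compound 1 `CCOC(=O)Cn1cnc2nc(Cl)nc(Cl)c21` gives 6360 nM;
compound 2 `CCOC(=O)Cn1cnc2ncnc(Cl)c21` gives 68000 nM.

Compound 2 stands at the higher of the two numbers; the step of an 11-fold higher number from compound 1 to compound 2 (1.03 log units; beyond the scatter) separates it from compound 1 in this assay. Compound 3 `CCOC(=O)Cn1cnc2ncnc(Br)c21` differs from compound 2 by a single change, (bromo in place of chloro on an aromatic carbon). Among the measured compounds shown here, no measured step exchanges one halogen for another. For the measured compounds named here, the only step on record, an 11-fold higher number from compound 1 to compound 2 (1.03 log units; beyond the scatter), concerns the loss of a chloro altogether and cannot be carried over to a swap that keeps a halogen in place, so it bears on the new step only indirectly. With no guidance for the exchange itself, no step beyond the scatter is expected in this assay. Compound 3 is therefore estimated at 50000 nM, within 20000 nM to 150000 nM. The expected step is a 1.4-fold lower number from compound 2 to compound 3 (0.13 log units; within the scatter).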

Compound 3, half-maximal inhibitory concentration: 55700 nM
Compound 3: middle estimate off by 1.1-fold (0.05 log units), on the low side; the measured number falls inside the stated range.
By their numbers in this assay, from the lowest: compound 1; then compounds 3 and 2 (each within the scatter of the next).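

In this assay, bromo in place of chloro on this aromatic carbon, next to the ring nitrogen, gives a 1.2-fold lower number from compound 2 to compound 3 (0.09 log units; within the scatter). The earlier compounds shown here showed only what the loss of a chloro on another aromatic carbon does, an 11-fold higher number from compound 1 to compound 2 (1.03 log units; beyond the scatter); this pair adds that, at this position, the chloro and the bromo cannot be told apart in this read-out. Nothing available accounts for this lack of difference.

The compounds shown leave open whether an amine or a thioether on this aromatic carbon, in place of the halogen, would move the number beyond the scatter. They also leave open whether the same exchange would read alike with the second chloro of compound 1 present, or with a carboxylic acid in place of the ethyl ester.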